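This account rests on a few compounds, and the source may have more. Where it says the series, first, only, none or still open, it means among the compounds named here.

Measured compounds:
- compound 1, `COc1cc(-c2cc(/C=C/C(C)=O)[nH]n2)cc(OC)c1OC`: 20100 nM
- compound 2, `COc1cc(-c2cc(/C=C3\CCc4ccccc4C3=O)[nH]n2)cc(OC)c1OC`: 8500 nM

Both were tested in a functional assay on MCF7 cells (Homo sapiens) for inhibition, read by MTT assay, with a stated time of 48 h; a lower number here means a stronger inhibitor, a higher number a weaker inhibitor. Compound 1 gives 20100 nM, the higher of the two numbers, so it is the weaker of the pair. Compound 2 gives 8500 nM, and the gap between the two lies beyond the usual scatter of such measurements, so compound 2 is genuinely the stronger one. Going by the values given here, compound 2 differs from compound 1 in more than one place, so no single step between them can be isolated.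

Compound 3, `COc1ccc(C(=O)/C=C/c2cc(-c3cc(OC)c(OC)c(OC)c3)n[nH]2)cc1OC`, has not yet been measured. It differs from compound 1 in one place: 3,4-dimethoxyphenyl in place of methyl on a carbonyl carbon. The ketone attached to the double bond is kept, but its small methyl end is exchanged for a larger aromatic group carrying two methoxy groups.

Among the compounds with values here, no measured pair shows this exact change. Since compound 2, which also carries a larger ring system at this end of the molecule, gives 8500 nM against compound 1 with 20100 nM, a step toward a lower number is expected from compound 1 to compound 3, estimated at a 5.7-fold lower number from compound 1 to compound 3 (0.76 log units; beyond the scatter). Compound 3 is therefore expected to give about 3500 nM, within a range from 700 nM to 15000 nM.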

Compound 3, half-maximal inhibitory concentration: 510 nM
Compound 3: middle estimate off by 6.9-fold (0.84 log units), on the high side; the measured number lies below the stated range.
By their numbers in this assay, from the lowest: compound 3; then compound 2; then compound 1.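

In this assay, going by these compounds alone, putting 3,4-dimethoxyphenyl in place of methyl on a carbonyl carbon gives a 39-fold lower number from compound 1 to compound 3 (1.60 log units; beyond the scatter) and this is the first single change here whose effect can be read on its own. It shows that this position, on a carbonyl carbon whose other neighbour is a double-bonded chain carbon, is not restricted to a small group: it accepts a much larger group containing an aromatic ring, and the number responds strongly to that exchange. No measurement shown here explains why the step is so large.

As far as these compounds go, this one step brings in the aromatic ring and its two methoxy groups together, so the share of each remains open, and an unsubstituted phenyl at the same place would be needed to separate them. Also open, from the compounds shown here alone, is how a saturated cyclohexyl ring, or a phenyl carrying a carboxylic acid or an amine, would behave at this position.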